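Sulfamoyl for ethoxycarbonyl: compound 3 to compound 4

A few compounds are considered here, and "the series" means these few. Any claim that something is new, unique, unknown or untested is made for them only; others in the source may bear on it.

Compound 3 `CCOC(=O)c1cc(Cc2ccccc2)c(O)c2ccccc12` holds the second highest of the three numbers in an assay on RBL-1 cells with Polyunsaturated fatty acid 5-lipoxygenase (Rattus norvegicus) as the target (on this read-out lower numbers stand for stronger inhibition and higher numbers for weaker inhibition), where compound 3 gives 160 nM. The lowest number belongs to compound 1 `Cc1cc(Cc2ccccc2)c(O)c2ccccc12`, which in this assay gives 20 nM; the highest belongs to compound 2 `O=C(O)c1cc(Cc2ccccc2)c(O)c2ccccc12`, which in this assay gives 5800 nM. Both steps ending at the ester were beyond the scatter: an 8.0-fold higher number from compound 1 to compound 3 (0.90 log units; beyond the scatter), and a 36-fold lower number from compound 2 to compound 3 (1.56 log units; beyond the scatter).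

Compound 4 `NS(=O)(=O)c1cc(Cc2ccccc2)c(O)c2ccccc12` differs from compound 3 by sulfamoyl in place of ethoxycarbonyl on an aromatic carbon. The step of a 36-fold lower number from compound 2 to compound 3 (1.56 log units; beyond the scatter) bears most on this change: that step took away the hydrogen-bond donor of the carboxy group, and the sulfamoyl entering in compound 4 brings a hydrogen-bond donor back onto the same aromatic carbon. A higher number than that of compound 3 is therefore expected in this assay, probably between the modest step and the large step seen so far. Compound 4 is estimated at 1500 nM, in a range from 300 nM to 8000 nM, which means the expected step of a 9.4-fold higher number from compound 3 to compound 4 (0.97 log units; beyond the scatter).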

Compound 4, half-maximal inhibitory concentration: 9400 nM
For compound 4 the middle estimate is 6.3-fold (0.80 log units) below the measured one; the measured number lies above the stated range.
By their numbers in this assay, from the lowest: compound 1; then compound 3; then compounds 2 and 4 (each within the scatter of the next).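

In this assay, sulfamoyl and carboxy on this aromatic carbon, para to a hydroxy group, cannot be told apart, at a 1.6-fold higher number from compound 2 to compound 4 (0.21 log units; within the scatter). Against the other two groups the change to sulfamoyl is large: a 59-fold higher number from compound 3 to compound 4 (1.77 log units; beyond the scatter) and a 470-fold higher number from compound 1 to compound 4 (2.67 log units; beyond the scatter). The high numbers at this carbon therefore no longer belong to carboxy alone, and ethoxycarbonyl and methyl both give lower numbers than these two groups. Nothing measured here accounts for this result.

What the compounds shown leave open is whether the loss follows the sulfamoyl nitrogen and its hydrogens or the sulfur-centred group as a whole. A methylsulfonyl group and a primary carboxamide on the same carbon would help to separate these two readings.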